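The compounds below may be only part of what the source reports. "The series", "measured", "known", "first", "only" and "open" are said of these compounds alone.

Of the compounds shown here, three on one shared core have been measured so far in a functional assay on MCF7 cells (Homo sapiens) for cytotoxicity, read by MTT assay, with a stated time of 96 h; on this read-out lower numbers stand for stronger inhibition and higher numbers for weaker inhibition. Compound 1 (`COc1cc(C(=O)c2cn(-c3ccccc3C)cc2-c2ccccc2)cc(OC)c1OC`) gives 2200 nM there, compound 2 (`COc1cc(C(=O)c2cn(-c3ccccc3[N+](=O)[O-])cc2-c2ccccc2)cc(OC)c1OC`) gives 5000 nM there, and compound 3 (`COc1cc(C(=O)c2cn(-c3ccccc3N)cc2-c2ccccc2)cc(OC)c1OC`) gives 3800 nM on the same read-out. Compound 3 lies within the scatter of both others, its two steps being (a 1.7-fold higher number from compound 1 to compound 3 (0.24 log units; within the scatter)) and (a 1.3-fold lower number from compound 2 to compound 3 (0.12 log units; within the scatter)). Among the compounds with values here, the only step beyond the scatter is modest (a 2.3-fold higher number from compound 1 to compound 2 (0.36 log units; beyond the scatter)). Compound 4 (`COc1ccccc1-n1cc(C(=O)c2cc(OC)c(OC)c(OC)c2)c(-c2ccccc2)c1`) carries one change from compound 3 (methoxy in place of amino on an aromatic carbon), namely methoxy in place of amino on an aromatic carbon, ortho to a large group. Within the data shown here, no measured compound carries methoxy, so the evidence is indirect: exchanging methyl, nitro and amino at this place has moved the number little, the largest step being the modest one above (a 2.3-fold higher number from compound 1 to compound 2 (0.36 log units; beyond the scatter)). No step beyond the scatter is therefore expected in this assay for this change (a 1.3-fold lower number from compound 3 to compound 4 (0.10 log units; within the scatter)). Compound 4 is estimated at 3000 nM as a central value (expected range from 1200 nM to 7000 nM).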

Compound 4, half-maximal inhibitory concentration: 150 nM
Estimate against measurement, compound 4: 20-fold (1.30 log units) above; measured number below the stated range.
By their numbers in this assay, from the lowest: compound 4; then compounds 1, 3 and 2 (each within the scatter of the next, the first and the last beyond it).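

In this assay, this position turns out to be far from indifferent: methoxy in place of amino gives a 25-fold lower number from compound 3 to compound 4 (1.40 log units; beyond the scatter), and methoxy in place of nitro or methyl gives a 33-fold lower number from compound 2 to compound 4 (1.52 log units; beyond the scatter) and a 15-fold lower number from compound 1 to compound 4 (1.17 log units; beyond the scatter). All three steps are large and beyond the scatter, so compound 4 is the most potent of the four, while the exchanges among methyl, nitro and amino had moved the number only a little, showing that this place can respond strongly to the group it carries. Nothing available alongside these numbers speaks to the reason for the difference.

The compounds shown leave open whether hydroxy or ethoxy at this place would also give a low number. They also leave open whether methoxy on another carbon of the same ring would do so.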